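Trading an Azide for an Amino Alcohol on the Shared Core

A few compounds are considered here, and "the series" means these few. Any claim that something is new, unique, unknown or untested is made for them only; others in the source may bear on it.

Compound 3 `CCCCCCCCCO[C@@H]1[C@@H](N)[C@@H](OC[C@H](O)CN=[N+]=[N-])O[C@H](CN)[C@H]1OCCCCCCCCC` stands lowest of the three compounds measured in a toxicity assay on the whole organism (J774 cells) for cytotoxicity, with Mus musculus as the target, read by MTT assay, with a stated time of 24 h, tested at 10 uM; on this read-out lower numbers stand for a stronger effect and higher numbers for a weaker effect at the one concentration tested: compound 3 gives 62.2%, whereas compound 1 `CCCCCCCCCO[C@@H]1[C@@H](N)[C@@H](O[C@H]2[C@H](O)[C@@H](O)[C@H](N)C[C@@H]2N)O[C@H](CN)[C@H]1OCCCCCCCCC` gives 82.7% and compound 2 `CCCCCCCCCO[C@@H]1[C@@H](N)[C@@H](OCC(O)CO)O[C@H](CN)[C@H]1OCCCCCCCCC` gives 89.7%. Both gaps lie beyond the scatter, a number 20.5 percentage points lower from compound 1 to compound 3 (beyond the scatter) and a number 27.5 percentage points lower from compound 2 to compound 3 (beyond the scatter), so compound 3 is the one with the strongest effect on this read-out. Compound 4 `CCCCCCCCCO[C@@H]1[C@@H](N)[C@@H](OCC(O)CNCCO)O[C@H](CN)[C@H]1OCCCCCCCCC` differs from compound 3 by a single change, (1-hydroxy-2-((2-hydroxyethyl)amino)ethyl in place of 2-azido-1-hydroxyethyl on a saturated chain carbon bound to an oxygen on a saturated carbon). Going by the values given here, the step that bears most on it is the one from compound 2 to compound 3, where 2-azido-1-hydroxyethyl replaced 1,2-dihydroxyethyl at the same place and the number fell clearly; the step from compound 1 to compound 3 points the same way. In compound 4 the 2-azido-1-hydroxyethyl leaves again and 1-hydroxy-2-((2-hydroxyethyl)amino)ethyl enters, a group nearer in kind to the 1,2-dihydroxyethyl of compound 2, so a step back upward is expected, of roughly a number 17.8 percentage points higher from compound 3 to compound 4 (beyond the scatter). Compound 4 is therefore estimated at 80%, with an expected range from 64% to 94%.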

Compound 4, a percentage reported as activity, at one concentration (the size of the read-out at that concentration, not a potency): 99.1%
The estimate for compound 4 lay 19.1 percentage points below the measured number; the whole stated range lies below it.
By their numbers in this assay, from the lowest: compound 3; then compounds 1, 2 and 4 (each within the scatter of the next, the first and the last beyond it).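

In this assay, replacing the 2-azido-1-hydroxyethyl of compound 3 with 1-hydroxy-2-((2-hydroxyethyl)amino)ethyl gives a number 36.9 percentage points higher from compound 3 to compound 4 (beyond the scatter) and shows that this place can carry a nitrogen group without the low number seen with the azide. With (2-hydroxyethyl)amino in place of hydroxy, the comparison gives a number 9.4 percentage points higher from compound 2 to compound 4 (within the scatter) and so does not separate the amino alcohol from the diol, whereas the comparison with the diamino cyclohexyl group gives a number 16.4 percentage points higher from compound 1 to compound 4 (beyond the scatter) and adds a separation that the diol did not show. No available evidence accounts for these steps.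

The compounds shown leave open whether a plain primary amine, a carboxylic acid or a longer chain at this place would stay with compound 2 and compound 4 or fall towards compound 3.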